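The source may report more compounds than this note shows. Statements on the series, on what has been measured and on what is new or still open speak of the compounds shown alone.

The measured compounds are:

Compound 1, `CNC(=O)CCc1ccncc1-c1ccc2ccccc2c1`, with 21.1 nM in an assay on a protein complex for inhibition of CDK8/Cyclin C (Homo sapiens), with a stated time of 1 h; on this read-out higher numbers stand for weaker inhibition and lower numbers for stronger inhibition.
Compound 2, `O=C(O)CCc1ccncc1-c1ccc2ccccc2c1`, with 50.5 nM in this assay.
Compound 3, `CNC(=O)/C=C/c1ccncc1-c1ccc2[nH]ccc2c1`, with 51.9 nM in this assay.

Compound 1 and compound 2 share a core and differ in one place only: hydroxy in place of methylamino on a carbonyl carbon. This change gave a 2.4-fold higher number from compound 1 to compound 2 (0.38 log units; beyond the scatter).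

Compound 3 carries a different core, and the difference between its core and that of compound 1 is not broken down here. Compound 3 and compound 2 give numbers that lie within the scatter of one another, so nothing can be said about their order; compound 3 does stand beyond the scatter from compound 1.

Compound 4, `O=C(O)/C=C/c1ccncc1-c1ccc2[nH]ccc2c1`, has not yet been measured. It is related to compound 3 in the following way: hydroxy in place of methylamino on a carbonyl carbon. This is the same kind of change as that from compound 1 to compound 2, but not the same: in compound 1 the carbonyl carbon has a saturated chain carbon as its other neighbour, whereas in compound 3 that neighbour is a double-bonded chain carbon, and the two cores differ as well.

For the measured compounds named here, with only one earlier instance of this change, in a different setting, the expectation for compound 4 rests on the assumption that the step repeats. Compound 4 is therefore expected to give a higher number than compound 3, a 2.2-fold higher number from compound 3 to compound 4 (0.35 log units; beyond the scatter), because the earlier change gave a 2.4-fold higher number from compound 1 to compound 2 (0.38 log units; beyond the scatter). The estimate for compound 4 in this assay is 115 nM, with a likely range from 55 nM to 240 nM.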

Compound 4, half-maximal inhibitory concentration: 17 nM
Beside the measured number, compound 4's estimate is 6.8-fold (0.83 log units) above it; the measured number lies below the stated range.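

In this assay, hydroxy in place of methylamino on a carbonyl carbon gave a 3.1-fold lower number from compound 3 to compound 4 (0.48 log units; beyond the scatter), so the change did not carry its earlier direction over to the second core, as the two instances show when set side by side: the same change on two cores in this assay, a 2.4-fold higher number (0.38 log units; beyond the scatter) from compound 1 to compound 2 and a 3.1-fold lower number (0.48 log units; beyond the scatter) from compound 3 to compound 4, 7.3-fold (0.86 log units) apart, beyond the scatter of two such steps. Within these four compounds, then, a step read on one pair did not hold for the other, and the change has to be judged in its own setting rather than transferred as a fixed increment. The result does not show what reverses the step: the two pairs differ both in the other neighbour of the carbonyl carbon, a saturated chain carbon in compound 1 and a double-bonded chain carbon in compound 3, and in the rest of the core, and each direction rests on a single pair.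

The compounds shown leave open whether the chain or the rest of the core decides the direction, since none of them joins the saturated chain to the core of compound 3 or the double-bonded chain to the core of compound 1. Going by these compounds, how a methyl ester or a primary amide in the same place would read on either core also remains open.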